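The source may report more compounds than this note shows. Statements on the series, on what has been measured and on what is new or still open speak of the compounds shown alone.

Values in a functional assay on HepG2 cells (Homo sapiens) for inhibition, read by MTT assay, with a stated time of 48 h; on this read-out higher numbers stand for weaker inhibition and lower numbers for stronger inhibition:
- Compound 1 `CCSc1nnc(-c2cc(OC)c(OC)c(OC)c2)n1-c1ccc(N(C)C)cc1`: > 60000 nM, a limit of the assay.
- Compound 2 `COc1ccc(CSc2nnc(-c3cc(OC)c(OC)c(OC)c3)n2-c2ccc(N(C)C)cc2)cc1`: > 60000 nM, a limit of the assay.
- Compound 3 `COc1cc(-c2nnc(SCc3ccc(F)cc3)n2-c2ccc(N(C)C)cc2)cc(OC)c1OC`: 26400 nM.

Compound 3 alone has a number. The rest of the series is the limit of > 60000 nM in this assay, at which 2 of the 3 values shown sit.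

Compound 4 `COc1cc(-c2nnc(SCC(=O)C3CC3)n2-c2ccc(N(C)C)cc2)cc(OC)c1OC` has cyclopropylcarbonyl in place of 4-fluorophenyl on a saturated chain carbon bound to a sulfur.

Among the compounds with values here, two measured steps bear on this change: an at least 2.2-fold lower number from compound 1 to compound 3 (0.35 log units; beyond the scatter) and an at least 2.2-fold lower number from compound 2 to compound 3 (0.35 log units; beyond the scatter). Both end at the 4-fluorophenyl group that compound 4 gives up, so a shift toward a higher number is expected. Compound 2 also carries an aromatic ring and reaches only a limit, so the new group offers no clear support for a gain.

Expected in this assay is a 1.3-fold higher number from compound 3 to compound 4 (0.12 log units; within the scatter). For compound 4 the estimate is 35000 nM, with an expected range of 10000 nM to 90000 nM.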

Compound 4, half-maximal inhibitory concentration: > 60000 nM
Compound 4: a limit, no number; the forecaster's own chance of this, stated with the estimate: 45%; middle value at least 1.7-fold (0.23 log units) from the limit.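

In this assay, cyclopropylcarbonyl on the saturated chain carbon bound to a sulfur gives an at least 2.2-fold higher number from compound 3 to compound 4 (0.35 log units; beyond the scatter), so this group does not keep the number seen with 4-fluorophenyl. The series now shows that a replacement without an aromatic ring also fails to give a number at this position. Among the groups shown here, only 4-fluorophenyl gives a number, and the others stay at the limit: the limit of > 60000 nM in this assay, at which 3 of the 4 values shown sit.

The steps joining compound 1, compound 2 and compound 4 cannot be read, as each has a limit at both ends. From the compounds shown here alone, whether 4-chlorophenyl or an amine on this chain carbon would give a number remains open.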